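This account rests on a few compounds, and the source may have more. Where it says the series, first, only, none or still open, it means among the compounds named here.

Measured in a functional assay on HeLa cells (Homo sapiens) for cytotoxicity, read by MTT assay, with a stated time of 24 h; a lower number here means a stronger inhibitor, a higher number a weaker inhibitor:
- compound 1 `COc1ccc(/C=C2\CN(C)C/C(=C\c3ccccc3F)C2=O)cc1`: 23500 nM
- compound 2 `COc1cc(/C=C2\CN(C)C/C(=C\c3ccc(Cl)c(Cl)c3)C2=O)cc(OC)c1`: 6900 nM
- compound 3 `CN1C/C(=C\c2ccc(F)cc2)C(=O)/C(=C/c2ccc(C#N)cc2)C1`: 10200 nM

Compound 3, at 10200 nM, lies within the scatter of compound 2 and beyond the scatter below compound 1. Compound 4 `CN1C/C(=C\c2ccc(C#N)cc2)C(=O)/C(=C/c2ccc(Cl)cc2Cl)C1` carries 2,4-dichlorophenyl in place of 4-fluorophenyl on a double-bonded chain carbon bound to a double-bonded ring carbon. Going by the values given here, no measured pair isolates this change. Among the compounds with values here, the only guide is compound 2, also a dichlorophenyl compound, at 6900 nM. A small step toward a lower number in this assay is therefore expected, possibly none beyond the scatter. The estimated step is a 1.4-fold lower number from compound 3 to compound 4 (0.13 log units; within the scatter). For compound 4 the estimated value is 7500 nM, with an expected range of 3200 nM to 17000 nM.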

Compound 4, half-maximal inhibitory concentration: 7760 nM
Beside the measured number, compound 4's estimate is 1.0-fold (0.01 log units) below it; low and high end bracket the measured number.
By their numbers in this assay, from the lowest: compounds 2, 4 and 3 (each within the scatter of the next); then compound 1.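

In this assay, going by these compounds alone, the swap of 4-fluorophenyl for 2,4-dichlorophenyl gives a 1.3-fold lower number from compound 3 to compound 4 (0.12 log units; within the scatter) and supplies the first pair that differs in one place. At this position, on a double-bonded chain carbon bound to a double-bonded ring carbon, the change stays within the scatter while the nitrile-bearing partner is held constant. No supporting measurement bears on the reason for this result. On these data alone, whether an amine or a carboxylic acid on the phenyl group at this position would shift the number beyond the scatter remains open. Also open, as far as these compounds go, is whether the same swap gives a similar step in compounds lacking the nitrile.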